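The source may report more compounds than this note shows. Statements on the series, on what has been measured and on what is new or still open speak of the compounds shown alone.

Compound 1 `C=C1C(=O)[C@]23C[C@@]1(O)CC[C@H]2c1ccc(OS(=O)(=O)c2ccc(C)cc2)c(C)c1[C@@H]3Cn1cc(-c2ccc(C)cc2)nn1` and compound 3 `C=C1C(=O)[C@]23C[C@@]1(O)CC[C@H]2c1ccc(OS(=O)(=O)c2ccc(C)cc2)c(C)c1[C@@H]3Cn1cc(-c2ccc(OC)cc2)nn1` share a core that carries a tosylate-bearing aromatic ring and a methylene-linked triazole. In a functional assay on MCF7 cells (Homo sapiens) for cytotoxicity, read by MTT assay, with a stated time of 4 days (on this read-out higher numbers stand for weaker inhibition and lower numbers for stronger inhibition), compound 1 gives 320 nM. In this assay compound 3 gives 310 nM. The change between them, (methoxy in place of methyl on an aromatic carbon), produced a 1.0-fold lower number from compound 1 to compound 3 (0.01 log units; within the scatter).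

Compound 2 `Cc1ccc(-c2cn(C[C@H]3c4c(ccc(O)c4C)[C@@H]4CC[C@@]5(C)C[C@]43CC5=O)nn2)cc1` has a different core, with a free phenol in place of the tosylate and a methyl-bearing ring system carrying the ketone; the difference between the two cores is not broken down here. In this assay compound 2 reaches only a limit, > 20000 nM.

Compound 4 `COc1ccc(-c2cn(C[C@H]3c4c(ccc(O)c4C)[C@@H]4CC[C@@]5(C)C[C@]43CC5=O)nn2)cc1` relates to compound 2 by the same change, (methoxy in place of methyl on an aromatic carbon), and the place is identical in both pairs. Since the step from compound 1 to compound 3 a 1.0-fold lower number from compound 1 to compound 3 (0.01 log units; within the scatter) was within the scatter, the step from compound 2 to compound 4 is expected to be of similar size, a step that the limit leaves unreadable from compound 2 to compound 4, and since the limit of > 20000 nM in this assay, at which 1 of the 3 values shown sits, describes where compound 2 sits, compound 4 is estimated to give 25000 nM in this assay, within 10000 nM and 60000 nM, most likely again as a limit.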

Compound 4, half-maximal inhibitory concentration: > 20000 nM
Compound 4: only a limit was reported; the forecaster's own chance of this, stated with the estimate: 80%; the middle value lies beyond the limit too.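

For the compounds shown here, compound 2 and compound 4 both stand only as limits in this assay, so no step between them can be read: the limit of > 20000 nM in this assay, at which 2 of the 4 values shown sit.

The compounds shown leave open whether going from 4-methylphenyl to 4-methoxyphenyl changes anything on the core of compound 2, and how a tosylate and a free phenol would compare on one shared core.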